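A Methyl-to-Fluoro Change at a Limit of the Assay

The source may report more compounds than this note shows. Statements on the series, on what has been measured and on what is new or still open speak of the compounds shown alone.

In a functional assay on MCF7 cells (Homo sapiens) for antiproliferative activity, read by MTT assay, with a stated time of 48 h (on this read-out higher numbers stand for weaker inhibition and lower numbers for stronger inhibition), compound 1 (`O=C(/C=C/c1ccc2c(c1)OCCO2)NS(=O)(=O)c1ccccc1`) reaches 2.16 ug/mL and compound 2 (`O=C(/C=C/c1ccc2c(c1)OCCCO2)NS(=O)(=O)c1ccccc1`) reaches 53.9 ug/mL on the same read-out. Compound 3 (`Cc1ccc(S(=O)(=O)NC(=O)/C=C/c2ccc3c(c2)OCCCO3)cc1`) shows > 100 ug/mL as a limit of the assay and not a number (the limit of > 100 ug/mL in this assay, at which 1 of the 3 values shown sits). Compound 4 (`O=C(/C=C/c1ccc2c(c1)OCCCO2)NS(=O)(=O)c1ccc(F)cc1`) carries fluoro in place of methyl on an aromatic carbon, para to a large group (fluoro in place of methyl on an aromatic carbon). For the measured compounds named here, the only measured step at that place is methyl in place of hydrogen (an at least 1.8-fold higher number from compound 2 to compound 3 (0.26 log units; that floor lies within the scatter)), and it gives only a floor within the scatter, so it fixes no size. Going by the values given here, no measured step involves fluoro, so the expectation leans on compound 2 (53.9 ug/mL), which has hydrogen at that place. In this assay the expected change is an at least 1.6-fold lower number from compound 3 to compound 4 (0.22 log units; that floor lies within the scatter) toward stronger inhibition, although a reading that stays at the limit remains possible. Compound 4 is estimated at 60 ug/mL (expected range 20 ug/mL to 100 ug/mL).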

Compound 4, half-maximal inhibitory concentration: > 100 ug/mL
Compound 4 gave a limit, no number; the forecaster's own chance of this, stated with the estimate: 35%; at least 1.6-fold (0.22 log units) between middle value and limit.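

In this assay compound 4 gives > 100 ug/mL, a limit of the assay and not a number. Fluoro in place of hydrogen at this place gives an at least 1.8-fold higher number from compound 2 to compound 4 (0.26 log units; that floor lies within the scatter), so fluoro, like methyl, fixes no size, and the step between compound 3 and compound 4 cannot be read, since both ends are limits. What is new is that two different groups at this place, methyl and fluoro, both end at the limit, which now holds more of the series: the limit of > 100 ug/mL in this assay, at which 2 of the 4 values shown sit.

The compounds shown leave open whether any group at this place, such as an amine or a carboxylic acid, would give a lower number than the hydrogen of compound 2, which gives 53.9 ug/mL. Also open, from the compounds shown here alone, is how fluoro or methyl at this place would read on the core of compound 1, which gives 2.16 ug/mL.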